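The source may report more compounds than this note shows. Statements on the series, on what has been measured and on what is new or still open speak of the compounds shown alone.

Three compounds have been measured so far:

Compound 1 `CC(C)(C)OC(=O)NCCNC(=O)CN1CN(c2ccccc2)C2(CCN(C(=O)c3ccc(C(C)(C)C)cc3)CC2)C1=O`: in an assay on HEK293 cells for displacement of a labelled ligand from NPC1-like intracellular cholesterol transporter 1 (Homo sapiens) (a higher number here means a weaker inhibitor, a lower number a stronger inhibitor), compound 1 gives 10900 nM.
Compound 2 `CC(C)(C)c1ccc(C(=O)N2CCC3(CC2)C(=O)N(CC(=O)N2CCN(S(C)(=O)=O)CC2)CN3c2ccccc2)cc1`: in this assay compound 2 gives 19000 nM.
Compound 3 `CC(C)(C)c1ccc(C(=O)N2CCC3(CC2)C(=O)N(CC(=O)NCCCCCNS(C)(=O)=O)CN3c2ccccc2)cc1`: in this assay compound 3 gives 5500 nM.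

Compound 3 has the lowest number of the three. Its nearest neighbour is compound 1, with a 2.0-fold lower number from compound 1 to compound 3 (0.30 log units; within the scatter), a step within the scatter. The step from compound 2 is larger, a 3.5-fold lower number from compound 2 to compound 3 (0.54 log units; beyond the scatter), and lies beyond the scatter, though it remains modest. The remaining comparison, a 1.7-fold higher number from compound 1 to compound 2 (0.24 log units; within the scatter), is also within the scatter.

Compound 4 `CC(C)(C)c1ccc(C(=O)N2CCC3(CC2)C(=O)N(CC(=O)NCCCCNS(C)(=O)=O)CN3c2ccccc2)cc1` differs from compound 3 in one place: methanesulfonamido in place of (methanesulfonamido)methyl on a saturated chain carbon, four bonds along the chain from an amide-type nitrogen. The chain carrying the methanesulfonamido group is thus shortened while the end group itself stays the same. Within the data shown here, none of the measured steps changes chain length alone; the two that touch this part of the molecule, a 2.0-fold lower number from compound 1 to compound 3 (0.30 log units; within the scatter) and a 3.5-fold lower number from compound 2 to compound 3 (0.54 log units; beyond the scatter), exchange the whole terminal group rather than trim the chain, and even they are modest. A shortened chain is therefore expected to give a step no larger than the scatter, a 1.1-fold higher number from compound 3 to compound 4 (0.04 log units; within the scatter), in either direction. Compound 4 is estimated at 6000 nM, with a range from 2500 nM to 14000 nM.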

Compound 4, half-maximal inhibitory concentration: 4500 nM
For compound 4 the middle estimate is 1.3-fold (0.12 log units) above the measured one, within the range that was stated.
By their numbers in this assay, from the lowest: compounds 4, 3, 1 and 2 (each within the scatter of the next, the first and the last beyond it).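

Among these compounds, replacing (methanesulfonamido)methyl with methanesulfonamido, four bonds along the chain from an amide-type nitrogen, is the first change here to alter chain length alone, and in this assay it gives a 1.2-fold lower number from compound 3 to compound 4 (0.09 log units; within the scatter) and so leaves the two compounds indistinguishable. The chain ending in methanesulfonamido also keeps its advantage over the 4-(methylsulfonyl)piperazin-1-yl amide, with a 4.2-fold lower number from compound 2 to compound 4 (0.63 log units; beyond the scatter) matching the modest step already seen for the longer chain, and no compound shown goes against this. The step of a 2.4-fold lower number from compound 1 to compound 4 (0.38 log units; beyond the scatter) is printed as beyond the scatter while the corresponding step to compound 3 is not, but that difference does not separate the two chain lengths, and nothing available explains any of these steps.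

The compounds shown leave open how far the chain can be changed in either direction, for example with a propyl chain or a hexyl chain carrying the same methanesulfonamido group. They also leave open whether another end group on the butyl chain, such as a primary amine or a carboxylic acid, would give a different number.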